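Halogenated benzylamines on a shared pyrazolopyrimidine-type core: compound 4

A few compounds are considered here, and "the series" means these few. Any claim that something is new, unique, unknown or untested is made for them only; others in the source may bear on it.

Measured compounds:
- compound 1, `Cc1cc(Nc2nc(Cl)nc3[nH]ncc23)n[nH]1`: 5940 nM
- compound 2, `Cc1cc(Nc2nc(NCc3ccccc3F)nc3[nH]ncc23)n[nH]1`: 389 nM
- compound 3, `Cc1cc(Nc2nc(NCc3ccccc3Br)nc3[nH]ncc23)n[nH]1`: 1090 nM

In an assay on isolated protein for inhibition of serine/threonine-protein kinase PAK 4 (Homo sapiens), read by HTRF, with a stated time of 60 min (on this read-out higher numbers stand for weaker inhibition and lower numbers for stronger inhibition), compound 3 gives 1090 nM, the second highest of the three numbers. Its nearest neighbour is compound 2, which in this assay gives 389 nM; the furthest is compound 1, which in this assay gives 5940 nM.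

Compound 4, `Cc1cc(Nc2nc(NCc3ccc(Cl)cc3)nc3[nH]ncc23)n[nH]1`, has not been measured. It differs from compound 3 in one place: 4-chlorophenyl in place of 2-bromophenyl on a saturated chain carbon bound to a nitrogen on an aromatic ring.

Within the data shown here, only one measured step bears on this change. From compound 2 to compound 3 the exchange of bromo for fluoro on the aromatic carbon gave a 2.8-fold higher number from compound 2 to compound 3 (0.45 log units; beyond the scatter). Among the measured compounds shown here, no measured pair shows the effect of 4-chlorophenyl against 2-bromophenyl, so the size of the step from compound 3 to compound 4 cannot be read directly from the data. Since the chloro-bearing ring is a halogenated benzyl like those of compound 2 and compound 3, compound 4 is expected to stay in the same region, with a modest decrease at most, a 1.6-fold lower number from compound 3 to compound 4 (0.19 log units; within the scatter). For compound 4 in this assay the estimate is 700 nM, in a range from 250 nM to 2000 nM.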

Compound 4, half-maximal inhibitory concentration: 515 nM
Estimate against measurement, compound 4: 1.4-fold (0.13 log units) above, within the range that was stated.
By their numbers in this assay, from the lowest: compounds 2 and 4 (each within the scatter of the next); then compound 3; then compound 1.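

Replacing 2-bromophenyl with 4-chlorophenyl on the saturated chain carbon gives, in this assay, a 2.1-fold lower number from compound 3 to compound 4 (0.33 log units; beyond the scatter) as a modest change, showing that this position responds when the halogen and its place on the ring change together. Set against the fluoro-bearing ring, the same 4-chlorophenyl group gives a 1.3-fold higher number from compound 2 to compound 4 (0.12 log units; within the scatter) and cannot be told apart from 2-fluorophenyl here, so among the three halogenated benzyl compounds only compound 3 stands apart from the other two. Nothing available explains why the numbers fall this way.

Because halogen and ring place change in a single step from compound 3 to compound 4, the compounds shown cannot say how much of that step belongs to each, and a chloro group at the ring place held by bromo in compound 3 would be needed to separate them. Also open, from the compounds shown here alone, is how the position behaves with a plain phenyl ring carrying no halogen, a ring bearing a methoxy group or a carboxylic acid, or a longer chain between the ring and the nitrogen.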